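Swapping the Aryl Group on the Doubly Bonded Carbon

A few compounds are considered here, and "the series" means these few. Any claim that something is new, unique, unknown or untested is made for them only; others in the source may bear on it.

For the measured compounds named here, in an assay on isolated protein for inhibition of Maltase-glucoamylase (Homo sapiens), with a stated time of 15 min (on this read-out higher numbers stand for weaker inhibition and lower numbers for stronger inhibition), compound 2 `COc1ccc(/C=N/NC(=O)c2ccc(-c3nc4ccccc4s3)cc2)c(O)c1` gives 6970 nM, the lower of the two numbers so far, while compound 1 `O=C(N/N=C/c1cccs1)c1ccc(-c2nc3ccccc3s2)cc1` gives 8480 nM. Going by the values given here, the one comparison available, a 1.2-fold lower number from compound 1 to compound 2 (0.09 log units; within the scatter), stays within the scatter. Compound 3 `COC(=O)c1ccc(/C=N/NC(=O)c2ccc(-c3nc4ccccc4s3)cc2)cc1` differs from compound 2 by 4-(methoxycarbonyl)phenyl in place of 2-hydroxy-4-methoxyphenyl on a carbon with a double bond to nitrogen. Since the earlier change of the aryl group at that same carbon, from compound 1 to compound 2, hardly moved this assay, no step beyond the scatter is expected here either, and compound 3 is estimated at 7500 nM (range 3000 nM to 18000 nM), a step of a 1.1-fold higher number from compound 2 to compound 3 (0.03 log units; within the scatter) expected.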

Compound 3, half-maximal inhibitory concentration: "not active" (no number reported)
Compound 3 has no reported number here; the estimate stays without a comparison.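

For the compounds shown here, compound 3 is reported only as "not active", without a number, so no step from compound 2 to compound 3 can be read. No evidence at hand bears on this result. The compounds shown leave open how 4-(methoxycarbonyl)phenyl compares numerically with 2-hydroxy-4-methoxyphenyl at that carbon.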